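The source may report more compounds than this note shows. Statements on the series, on what has been measured and on what is new or still open speak of the compounds shown alone.

Measured compounds:
compound 1 `COCCNc1nc(C)nc2c1nnn2-c1c(C)cc(C)cc1C` gives 1200 nM in an in vitro assay on 293-EBNA cells for binding affinity to corticotropin-releasing factor receptor 1 (Homo sapiens); on this read-out lower numbers stand for stronger inhibition and higher numbers for weaker inhibition
compound 2 `Cc1nc(N2CCCC2)c2nnn(-c3ccc(C(C)C)cc3Br)c2n1` gives 194 nM
compound 3 `CCN(CC)c1nc(C)nc2c1nnn2-c1ccc(C(C)C)cc1Br` gives 25.3 nM

Compound 3 gives the lowest number of the three. The nearest neighbour differs only at the amine nitrogen of the shared core: a 7.7-fold lower number from compound 2 to compound 3 (0.88 log units; beyond the scatter). Compound 1 stands furthest away, but it differs from compound 3 in two places, so only its value is shown and no single step can be drawn from it.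

Compound 4 `CCN(c1nc(C)nc2c1nnn2-c1ccc(C(C)C)cc1Br)C(COC)COC` differs from compound 3 by 2-methoxy-1-(methoxymethyl)ethyl in place of ethyl on a nitrogen on an aromatic ring. Going by the values given here, no measured step covers this exchange. Among the compounds with values here, the one step in hand, a 7.7-fold lower number from compound 2 to compound 3 (0.88 log units; beyond the scatter), sits on the same nitrogen and shows that changes at this amine can move the number well beyond the scatter; the direction for a longer, ether-bearing chain is not read from the data. The step is therefore expected to stay within or close to the scatter: a 1.3-fold lower number from compound 3 to compound 4 (0.10 log units; within the scatter). Compound 4 is expected to give about 20 nM, with a range of 5 nM to 80 nM.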

Compound 4, inhibition constant: 123 nM
Beside the measured number, compound 4's estimate is 6.2-fold (0.79 log units) below it; measured number above the stated range.
By their numbers in this assay, from the lowest: compound 3; then compounds 4 and 2 (each within the scatter of the next); then compound 1.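

In this assay, 2-methoxy-1-(methoxymethyl)ethyl in place of ethyl on this nitrogen gives a 4.9-fold higher number from compound 3 to compound 4 (0.69 log units; beyond the scatter), so this exchange on the amine nitrogen moves the number beyond the scatter, upward in this case. Against the pyrrolidin-1-yl group on the aromatic carbon, the ether-bearing amine gives a 1.6-fold lower number from compound 2 to compound 4 (0.20 log units; within the scatter), which leaves diethylamino as the only one of these three amines with a step beyond the scatter to each of the other two. No available evidence bears on why this exchange raises the number.

As far as these compounds go, it remains open whether the rise follows the two ether oxygens or the carbon chain that carries them. An isopropyl group or a butyl chain in place of ethyl on this nitrogen would bear on that question.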